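The source may hold more compounds than are shown below. What is called first, only, known or untested is meant among the compounds shown, and "the series" means these compounds.

Among the compounds with values here, in a functional assay on isolated protein for antagonist activity at C-C chemokine receptor type 9 (Homo sapiens), read by calcium flux, with a stated time of 10 min (a lower number here means a stronger inhibitor, a higher number a weaker inhibitor), compound 2 `CCNc1nccnc1-c1cc(Cl)ccc1NS(=O)(=O)c1ccc(C(C)(C)C)cc1` gives 421 nM, the lowest of the two numbers so far; compound 1 `CC(C)(C)c1ccc(S(=O)(=O)Nc2ccc(Cl)cc2-c2ncccc2CN)cc1` gives 3160 nM. Within the data shown here, the only measured step, a 7.5-fold lower number from compound 1 to compound 2 (0.88 log units; beyond the scatter), swaps one aromatic ring for another and leaves the ethylamino chain untouched. Compound 3 `CC(C)(C)c1ccc(S(=O)(=O)Nc2ccc(Cl)cc2-c2nccnc2NCCO)cc1` differs from compound 2 by hydroxy in place of hydrogen on a saturated chain carbon, two bonds along the chain from a nitrogen on an aromatic ring. Among the measured compounds shown here, no measured step speaks to this change, so nothing beyond the scatter is assumed in this assay. Compound 3 is therefore expected near 400 nM, within a range of 130 nM to 1300 nM. The estimated step of a 1.1-fold lower number from compound 2 to compound 3 (0.02 log units; within the scatter) is expected to stay within the scatter.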

Compound 3, half-maximal inhibitory concentration: 34 nM
For compound 3 the middle estimate is 12-fold (1.07 log units) above the measured one, and the stated range ends above it.
By their numbers in this assay, from the lowest: compound 3; then compound 2; then compound 1.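

In this assay, within the data shown here, going from ethylamino to (2-hydroxyethyl)amino gives a 12-fold lower number from compound 2 to compound 3 (1.09 log units; beyond the scatter), so the saturated chain carbon two bonds along the chain from a nitrogen on an aromatic ring responds strongly to hydroxy, a place the one earlier step did not probe. Replacing the whole group on the aromatic carbon now gives a 93-fold lower number from compound 1 to compound 3 (1.97 log units; beyond the scatter), against a 7.5-fold lower number from compound 1 to compound 2 (0.88 log units; beyond the scatter) without the hydroxy. No supporting measurement bears on this result.

Open, on these data alone, is whether the hydroxy itself is required, or whether a methoxy, an amine, a carboxylic acid or a longer chain such as 3-hydroxypropyl would serve at this place.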